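From Methyl to Cyanophenylsulfonyl on the Ring Nitrogen

The source may hold more compounds than are shown below. What is called first, only, known or untested is meant among the compounds shown, and "the series" means these compounds.

Compound 1 `COc1ccc(-c2cc(=O)c3c(OC)cc(OC)cc3n2C)cc1` gives 28000 nM in a functional assay on SUP-B15 cells (Homo sapiens) for antiproliferative activity, with a stated time of 72 h; a higher number here means that more compound is needed for the effect, a lower number that less compound is needed.
Compound 2 `COc1ccc(-c2[nH]c3cc(OC)cc(OC)c3c(=O)c2I)cc1` gives only a limit in this assay, > 86200 nM.
Compound 3 `COC(=O)c1cc(=O)c2c(OC)cc(OC)cc2n1C` gives only a limit in this assay, > 37900 nM.

Among the three measured compounds, compound 1 supplies the only actual number; the other two values are limits of the assay and not numbers. For the measured compounds named here, the single measured step between compounds that differ in one place, an at least 1.3-fold higher number from compound 1 to compound 3 (0.13 log units; that floor lies within the scatter), is itself bounded by a limit (the limit of > 37900 nM in this assay, at which 1 of the 3 values shown sits), and its floor lies within the usual scatter.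

Compound 4 `COc1ccc(-c2cc(=O)c3c(OC)cc(OC)cc3n2S(=O)(=O)c2ccc(C#N)cc2)cc1` differs from compound 1 at another position entirely: (4-cyanophenyl)sulfonyl in place of methyl on an aromatic nitrogen. Going by the values given here, the one measured step changes a group on an aromatic carbon, so nothing measured bears directly on a change at the ring nitrogen. With compound 1 already requiring a high concentration, compound 4 is expected to land near it, and a limit rather than a number is a real possibility. For compound 4 the estimated value is 35000 nM, with a range of 10000 nM to 120000 nM. The step this estimate means, a 1.3-fold higher number from compound 1 to compound 4 (0.10 log units; within the scatter), is expected to stay within the scatter.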

Compound 4, half-maximal effective concentration: 7900 nM
For compound 4 the middle estimate is 4.4-fold (0.65 log units) above the measured one; the measured number lies below the stated range.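

For the compounds shown here, at the ring nitrogen, putting (4-cyanophenyl)sulfonyl in place of methyl gives a 3.5-fold lower number from compound 1 to compound 4 (0.55 log units; beyond the scatter) in this assay, the first step that is a measured change beyond the scatter, though a modest one. The earlier step, on an aromatic carbon, was bounded by a limit with a floor within the scatter, whereas this one shows that the aromatic nitrogen can carry a far larger group than methyl without any loss in this assay. Nothing among the values shown accounts for this gain.

The compounds shown leave open which part of the entering group carries the step, as the sulfonyl, the aromatic ring and the nitrile all arrive together. From the compounds shown here alone, how an acetyl group on the ring nitrogen, or an amine in place of the nitrile, would read in this assay also remains open.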